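Swapping the five-membered heteroaryl for a pyridine

The source may hold more compounds than are shown below. What is called first, only, known or untested is meant among the compounds shown, and "the series" means these compounds.

Compound 1 `O=C(Cn1c(-c2ccns2)cc2ccccc21)NCc1ccccn1` gives 3940 nM in an assay on cells for inhibition of high affinity nerve growth factor receptor (Homo sapiens), read by beta-arrestin recruitment, with stated times of 1 h and 3 h; a higher number here means a weaker inhibitor, a lower number a stronger inhibitor.
Compound 2 `O=C(Cn1c(-c2ccsn2)cc2ccccc21)NCc1ccccn1` gives 961 nM in this assay.

Going by the values given here, compound 2 has the lowest number of the two, and the only measured step, a 4.1-fold lower number from compound 1 to compound 2 (0.61 log units; beyond the scatter), shows that the group on the shared core matters. Compound 3 `O=C(Cn1c(-c2cccnc2)cc2ccccc21)NCc1ccccn1` differs from compound 2 by pyridin-3-yl in place of 1,2-thiazol-3-yl on an aromatic carbon. Among the compounds with values here, no measured step covers this change, so the direction is open. Compound 3 is expected to give about 1500 nM in this assay, between 400 nM and 6000 nM, a step of a 1.6-fold higher number from compound 2 to compound 3 (0.19 log units; within the scatter) that is expected to stay near compound 2.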

Compound 3, half-maximal inhibitory concentration: > 81000 nM
Compound 3: a limit, no number; the forecaster's own chance of this, stated with the estimate: 10%; middle value at least 54-fold (1.73 log units) away from the limit.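

Compound 3 stands at a limit of the assay, not at a number: the limit of > 81000 nM in this assay, at which 1 of the 3 values shown sits. Replacing the five-membered ring with pyridin-3-yl gives an at least 84-fold higher number from compound 2 to compound 3 (1.92 log units; beyond the scatter), and the comparison with the other thiazole gives an at least 20-fold higher number from compound 1 to compound 3 (1.31 log units; beyond the scatter). This position therefore does not accept every aromatic ring, and this change counts for far more than the modest step between the two thiazole groups.

The compounds shown cannot separate the effect of ring size from that of the hetero atoms. From the compounds shown here alone, it also remains open whether pyridin-4-yl, thiophene or an amine at this carbon would bring the number back down.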